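The compounds below may be only part of what the source reports. "The series", "measured", "known", "first", "only" and "open" are said of these compounds alone.

Compound 1 `O=C1C=C(N2CC2)C(=O)c2nc(-c3ccccc3)ccc21` gives 85.1 nM in a functional assay on NCI60 cells (Homo sapiens) for cytotoxicity (on this read-out higher numbers stand for weaker inhibition of growth and lower numbers for stronger inhibition of growth), while compound 2 `O=C1C=C(NCc2ccccc2)C(=O)c2nc(-c3ccccc3)ccc21` gives 33100 nM in this assay. The change between them, (benzylamino in place of aziridin-1-yl on a double-bonded ring carbon), made the step of a 390-fold higher number from compound 1 to compound 2 (2.59 log units; beyond the scatter). Compound 3 `O=C1C(N2CC2)=CC(=O)c2nc(-c3ccccc3)ccc21` has the same atoms as compound 1 joined differently; the difference between the two cores is not broken down here. In this assay compound 3 gives 27.5 nM, the lowest number among the three measured compounds. Compound 4 `O=C1C(NCc2ccccc2)=CC(=O)c2nc(-c3ccccc3)ccc21` has not yet been measured. It differs from compound 3 by benzylamino in place of aziridin-1-yl on a double-bonded ring carbon, which is the same change as that from compound 1 to compound 2, on the same kind of place. Among the compounds with values here, since this single precedent is large, a step of similar size is expected, a 390-fold higher number from compound 3 to compound 4 (2.59 log units; beyond the scatter), because a 390-fold higher number from compound 1 to compound 2 (2.59 log units; beyond the scatter) is the only guide available. Compound 4 is expected to give about 10700 nM, with a likely span from 2500 nM to 45000 nM.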

Compound 4, concentration for 50% growth inhibition: 1700 nM
Compound 4: middle estimate off by 6.3-fold (0.80 log units), on the high side, outside the stated range (below it).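

In this assay, benzylamino in place of aziridin-1-yl on the second core gives a 62-fold higher number from compound 3 to compound 4 (1.79 log units; beyond the scatter), so the direction of the change and its large size both hold on the two cores shown. The exact size does not carry over, however, and the two steps differ: the same change on two cores in this assay, a 390-fold higher number (2.59 log units; beyond the scatter) from compound 1 to compound 2 and a 62-fold higher number (1.79 log units; beyond the scatter) from compound 3 to compound 4, 6.3-fold (0.80 log units) apart, beyond the scatter of two such steps. These two pairs show that the core can alter the size of this step, but they do not show which difference between the cores is responsible, or how the step would behave on any other core.

The compounds shown leave open whether a similar rise would follow with a smaller amine such as methylamino, or with a cyclic amine such as morpholine, on either core.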